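Methoxy on the dienone series: expected cytotoxicity step

The compounds below may be only part of what the source reports. "The series", "measured", "known", "first", "only" and "open" are said of these compounds alone.

- compound 1 `O=C(/C=C/C=C/c1ccccc1)c1ccccc1` gives (44300 nM)
- compound 2 `O=C(/C=C/C=C/c1ccccc1)c1ccccc1O` has no reported result ("not determined" (no result reported))
- compound 3 `O=C(/C=C/C=C/c1ccccc1)c1cccc(O)c1` gives (48700 nM)

For the measured compounds named here, all of these readings come from an ADME assay on RAW264.7 cells (Mus musculus) for cytotoxicity, read by MTT assay (on this read-out higher numbers stand for weaker inhibition and lower numbers for stronger inhibition), and only two numbers are available. Compound 1 stands within the scatter of compound 3, and compound 2 cannot be placed. The next compound to be measured is compound 4 `COc1ccc(C(=O)/C=C/C=C/c2ccccc2)cc1`, which carries methoxy in place of hydrogen on an aromatic carbon. Going by the values given here, only one measured step bears on this change: hydroxy in place of hydrogen on an aromatic carbon, which gives a 1.1-fold higher number from compound 1 to compound 3 (0.04 log units; within the scatter). That step involves a different group, so it is indirect evidence, and a single step cannot show a trend. No step beyond the scatter is therefore expected in this assay, and no direction is favoured. The expected step is a 1.0-fold higher number from compound 1 to compound 4 (0.01 log units; within the scatter). For compound 4 the estimated value is 45000 nM, with an expected range from 20000 nM to 95000 nM.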

Compound 4, half-maximal inhibitory concentration: > 100000 nM
Compound 4 was reported as a limit (the forecaster's own chance of this, stated with the estimate: 10%); middle value at least 2.2-fold (0.34 log units) away from the limit.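

For the compounds shown here, this is the first step beyond the scatter: in this assay, methoxy in place of hydrogen on an aromatic carbon, para to a large group, gives an at least 2.2-fold higher number from compound 1 to compound 4 (0.35 log units; beyond the scatter), whereas the earlier hydroxy step gave a 1.1-fold higher number from compound 1 to compound 3 (0.04 log units; within the scatter). In this assay compound 4 gives > 100000 nM, which is a limit and not a number. The step therefore fixes a direction for this change at this position, but its full size stays unknown: the limit of > 100000 nM in this assay, at which 1 of the 4 values shown sits.

The compounds shown do not separate the effect of methoxy itself from that of its position, as none carries hydroxy at this place or methoxy at another. On these data alone, whether an amine, a carboxylic acid or a longer alkoxy chain at this place would give a step of similar direction also stays open.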